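Alkoxy in place of alkylamino on the shared core

The source may report more compounds than this note shows. Statements on the series, on what has been measured and on what is new or still open speak of the compounds shown alone.

Compound 3 `CCCCNc1nc(N)c2nc(O)n(Cc3ccccc3)c2n1` gives the lowest number of the three in a functional assay on the whole organism for activation, with Mus musculus as the target (a higher number here means that more compound is needed for the effect, a lower number that less compound is needed), at 0.1 mg/kg. Compound 2 `CCCCCNc1nc(N)c2nc(O)n(Cc3ccccc3)c2n1` gives 0.3 mg/kg, and compound 1 `Cc1nc(N)c2nc(O)n(Cc3ccccc3)c2n1` gives 3 mg/kg. The steps of a 30-fold lower number from compound 1 to compound 3 (1.48 log units; beyond the scatter) and a 10-fold lower number from compound 1 to compound 2 (1.00 log units; beyond the scatter) show the gain from the chain-bearing amine, while a 3.0-fold lower number from compound 2 to compound 3 (0.48 log units; beyond the scatter) shows the shorter chain preferred. Compound 4 `CCCCCOc1nc(N)c2nc(O)n(Cc3ccccc3)c2n1` carries pentyloxy in place of butylamino on an aromatic carbon. Within the data shown here, this change lengthens the chain, which in compound 2 cost a modest step against compound 3, and swaps the donor for an oxygen, for which no measured step exists. A modest step to a higher number is therefore expected, a 3.0-fold higher number from compound 3 to compound 4 (0.48 log units; beyond the scatter). Compound 4 is estimated at 0.3 mg/kg, with a range of 0.1 mg/kg to 1 mg/kg.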

Compound 4, minimum effective dose: 0.3 mg/kg
Compound 4: middle estimate and measured number agree at the digits printed, within the range that was stated.
By their numbers in this assay, from the lowest: compound 3; then compounds 2 and 4 (each within the scatter of the next); then compound 1.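

Working notes: in this assay, pentyloxy in place of pentylamino on this aromatic carbon gives no change at the digits printed from compound 2 to compound 4 (within the scatter), so for the pentyl chain the amine hydrogen-bond donor is not required here. The gain over methyl persists with the oxygen link, at a 10-fold lower number from compound 1 to compound 4 (1.00 log units; beyond the scatter). The step of a 3.0-fold higher number from compound 3 to compound 4 (0.48 log units; beyond the scatter) changes both chain and linking atom, so it cannot be assigned to either alone.

Butoxy at this carbon would separate those two changes, and whether oxygen matches nitrogen with the butyl chain remains open. No available evidence explains why the oxygen and nitrogen links read alike.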